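A Halogen Swap on the Carbonyl Side

The source may report more compounds than this note shows. Statements on the series, on what has been measured and on what is new or still open speak of the compounds shown alone.

Compound 2 `Cc1cc(Cl)ccc1C(=O)Nc1ccc(S(=O)(=O)Nc2ccccc2)cc1` is tested in a functional assay on HEK293 cells for agonist activity at probable G-protein coupled receptor 27 (Homo sapiens), read by a luciferase reporter and beta-arrestin recruitment, with a stated time of 10 min (a lower number here means that less compound is needed, a higher number that more compound is needed for the effect), and gives 912 nM. Compound 1 `O=C(Nc1ccc(S(=O)(=O)NCc2ccccc2)cc1)c1ccc(Cl)cc1Cl` reaches only the assay limit, > 100000 nM, which is a boundary rather than a number. Among the values shown, compound 2 thus holds the only measured number, the other entry being a limit (the limit of > 100000 nM in this assay, at which 1 of the 2 values shown sits). Compound 3 `O=C(Nc1ccc(S(=O)(=O)Nc2ccccc2)cc1)c1ccc(I)cc1F` differs from compound 2 by 2-fluoro-4-iodophenyl in place of 4-chloro-2-methylphenyl on a carbonyl carbon. Going by the values given here, no measured step of this kind exists, and for this exchange of one substituted ring for another no shift beyond the usual scatter is expected in this assay. Compound 3 is therefore estimated at 1000 nM, between 250 nM and 5000 nM. The expected step is a 1.1-fold higher number from compound 2 to compound 3 (0.04 log units; within the scatter).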

Compound 3, half-maximal effective concentration: 5130 nM
Compound 3: middle estimate off by 5.1-fold (0.71 log units), on the low side; the whole stated range lies below it.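

On a carbonyl carbon whose other neighbour is an amide-type nitrogen, the ring is not freely exchangeable: replacing 4-chloro-2-methylphenyl with 2-fluoro-4-iodophenyl, a group with the same count of heavy atoms, gives a 5.6-fold higher number from compound 2 to compound 3 (0.75 log units; beyond the scatter) in this assay. This position therefore responds to what the ring carries, even without a change in ring type or size. Nothing shown here explains this shift. The compounds shown do not separate the contributions of the individual ring substituents, which all differ at once. Also open, going by these compounds, is how a ring carrying an amine or a carboxylic acid would fare here.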